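The compounds below may be only part of what the source reports. "The series", "measured", "known", "first", "only" and "open" are said of these compounds alone.

Measured compounds:
compound 1 `CC(C)=CCC1Cc2c(O)cc(=O)n(CCCO)c2CC1(C)C` — 0%
compound 2 `CC(C)=CCC1Cc2c(OCCCNC(=O)c3ccco3)cc(=O)n(CCCO)c2CC1(C)C` — 4.3%
compound 3 `CC(C)=CCC1Cc2c(OC(=O)Nc3cccc(F)c3)cc(=O)n(CCCO)c2CC1(C)C` — 0%

In a functional assay on PANC-1 cells (Homo sapiens) for inhibition, read by MTT assay, with a stated time of 24 h, tested at 10 uM (on this read-out higher numbers stand for more inhibition at the one concentration tested (going by the name of the read-out) and lower numbers for less inhibition), compound 1 gives 0%, the same number as compound 3, and compound 2 lies within the scatter of both. Compound 4 `CC(C)=CCC1Cc2c(OC(=O)Nc3ccc(F)cc3F)cc(=O)n(CCCO)c2CC1(C)C` is not yet measured; it differs from compound 1 by (2,4-difluorophenyl)carbamoyl in place of hydrogen on an oxygen on an aromatic ring. The closest measured step is no change at the digits printed from compound 1 to compound 3 (within the scatter), which also places a carbamoyl group on the same oxygen; the other step on that oxygen is a number 4.3 percentage points higher from compound 1 to compound 2 (within the scatter). Neither substitution moved this assay beyond the scatter, so for compound 4 no step beyond the scatter is expected, a number 2 percentage points higher from compound 1 to compound 4 (within the scatter). Compound 4 is therefore estimated at 2%, with a range from 0% to 12%, pending measurement.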

Compound 4, a percentage reported as inhibition, at one concentration (the size of the read-out at that concentration, not a potency): 0%
Compound 4: the middle estimate sits 2 percentage points above what was measured; measured number inside the range.
By their numbers in this assay, from the lowest: compounds 1, 3, 4 and 2 (each within the scatter of the next).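

In the series read by this assay, 2,4-difluorophenyl in place of 3-fluorophenyl on the amide-type nitrogen changes nothing beyond the scatter (no change at the digits printed from compound 3 to compound 4 (within the scatter)), and the full (2,4-difluorophenyl)carbamoyl group on the oxygen does the same (no change at the digits printed from compound 1 to compound 4 (within the scatter)). The carbamoyl and the 3-(((furan-2-yl)carbonyl)amino)propyl groups also stay within the scatter of each other (a number 4.3 percentage points lower from compound 2 to compound 4 (within the scatter)), so a second fluorine-bearing aryl carbamoyl adds no separation at this oxygen. No measured evidence bears on this result.

Open, going by these compounds, is whether any group on this oxygen moves the number beyond the scatter, for example a phenyl carbamoyl carrying a carboxylic acid or an amine.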